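The source may hold more compounds than are shown below. What is called first, only, known or untested is meant among the compounds shown, and "the series" means these compounds.

Compound 2, `CCCCCCCCC[C@@H](O)[C@@H](N)[C@@H](C)CC`, stands second highest of the three numbers measured in a functional assay on T47D cells (Homo sapiens) for antiproliferative activity, read by sulforhodamine B assay, with a stated time of 48 h (a lower number here means a stronger inhibitor of growth, a higher number a weaker inhibitor of growth), where compound 2 gives 14000 nM. Its nearest neighbour is compound 1, `CCCCCCCCCCCCCCC[C@@H](O)[C@@H](N)[C@@H](C)O`; in this assay compound 1 gives 19000 nM, a gap that lies within the scatter. Far from both is compound 3, `CCCCCCCCCCCCCCC[C@@H](O)[C@H](C)N`, for which this assay returns 900 nM. Among the compounds with values here, the one measured step in this set, a 21-fold lower number from compound 1 to compound 3 (1.32 log units; beyond the scatter), is large and runs toward a lower number.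

Compound 4, `CCCCCCCCC[C@@H](O)[C@@H](N)[C@@H](C)O`, has not yet been measured. It differs from compound 2 by hydroxy in place of ethyl on a saturated chain carbon bound to two saturated chain carbons. Within the data shown here, no measured pair carries exactly this change. The step from compound 1 to compound 3 removes a hydroxy-bearing group rather than introducing one, and the change from compound 2 to compound 4 points the other way, so it bears only loosely on it. Compound 1, which keeps the hydroxy, and compound 2, which carries the ethyl, sit within the scatter of each other, yet their chains also differ, so that comparison does not isolate the change either. Among the measured compounds shown here, with no direct precedent, compound 4 is expected to land close to compound 2, with a step of a 1.6-fold higher number from compound 2 to compound 4 (0.20 log units; within the scatter) in this assay. The estimate for compound 4 is 22000 nM, with a range from 8000 nM to 60000 nM.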

Compound 4, concentration for 50% growth inhibition: 16000 nM
Estimate against measurement, compound 4: 1.4-fold (0.14 log units) above, within the range that was stated.
By their numbers in this assay, from the lowest: compound 3; then compounds 2, 4 and 1 (each within the scatter of the next).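

In this assay, hydroxy in place of ethyl on a saturated chain carbon bound to two saturated chain carbons gives a 1.1-fold higher number from compound 2 to compound 4 (0.06 log units; within the scatter), so on this shorter chain the two groups cannot be told apart by this read-out. Within the data shown here, the new compound also isolates the chain for the first time: hydrogen in place of hexyl on a saturated chain carbon gives a 1.2-fold lower number from compound 1 to compound 4 (0.07 log units; within the scatter), and with the hydroxy kept, removing the hexyl leaves the number within the scatter. No independent measurement is available to explain either result.

Among these compounds, the only large change in this set remains a 21-fold lower number from compound 1 to compound 3 (1.32 log units; beyond the scatter), and it is open whether methyl in place of 1-hydroxyethyl would have a similar effect on the shorter chain of compound 4. Going by these compounds, it is also open whether an amine or a carboxylic acid at the position of the ethyl, or a longer chain carrying the ethyl, would move the number beyond the scatter.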